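The source may hold more compounds than are shown below. What is called first, only, known or untested is meant among the compounds shown, and "the series" means these compounds.

Measured compounds, in a functional assay on Jurkat cells (Homo sapiens) for inhibition; on this read-out lower numbers stand for stronger inhibition and higher numbers for weaker inhibition:
compound 1 `CCCCCCCCCCCCCCC(N)COCc1ccccc1` — 3000 nM
compound 2 `CCCCCCCCCCCCCCC(COCc1ccccc1)NCC(=O)O` — 3000 nM
compound 3 `CCCCCCCCCCCCCCC(CO)NC(=O)CCCC(=O)O` — 24000 nM

Compound 2 stands level with compound 1 and, together with it, gives the lowest number of the three; compound 3 lies furthest off. The step from compound 1 to compound 2 was flat: no change at the digits printed from compound 1 to compound 2 (within the scatter). Compound 4 `CCCCCCCCCCCCCCC(COCc1ccccc1)NC(=O)CCC(=O)O` carries the change ((2-carboxyethyl)carbonyl in place of carboxymethyl on an amine nitrogen). Within the data shown here, no measured step covers this amide for acid exchange directly; compound 3, which also bears an acid amide on the nitrogen but differs in a second place too, shows the highest number in this assay. A somewhat weaker read-out is therefore expected for compound 4, estimated as 8000 nM (range 3000 nM to 25000 nM), a step of a 2.7-fold higher number from compound 2 to compound 4 (0.43 log units; beyond the scatter).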

Compound 4, half-maximal inhibitory concentration: 30000 nM
The estimate for compound 4 lay 3.8-fold (0.57 log units) below the measured number, outside the stated range (above it).
By their numbers in this assay, from the lowest: compounds 1 and 2 (each within the scatter of the next); then compounds 3 and 4 (each within the scatter of the next).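

In this assay, the amine nitrogen proves sensitive to its substituent: (2-carboxyethyl)carbonyl in place of carboxymethyl gives a 10-fold higher number from compound 2 to compound 4 (1.00 log units; beyond the scatter), although the earlier step at this nitrogen was flat. Measured against the free amine, the same group gives a 10-fold higher number from compound 1 to compound 4 (1.00 log units; beyond the scatter), so a carboxylic acid on the nitrogen substituent does not by itself fix the read-out, as compound 2 and compound 4 both carry one. Nothing at hand explains this loss.

The amide carbonyl and the longer acid chain change together here, so their shares remain unseparated. An acetyl amide, or an amine bearing a longer carboxyalkyl chain, would address this.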